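A few compounds are considered here, and "the series" means these few. Any claim that something is new, unique, unknown or untested is made for them only; others in the source may bear on it.

Measured so far:
compound 1 `C/C=C/C(=O)Nc1cccc(Cn2nc(-c3ccc(Oc4ccccc4)cc3)cc2C(=O)O)c1`: > 60000 nM
compound 2 `O=C(O)c1cc(-c2ccc(Oc3ccccc3)cc2)nn1C1CCCN(C(=O)CCl)C1`: 3600 nM

Both results come from a functional assay on JeKo-1 cells (Homo sapiens) for inhibition, read by luminescence and CellTiter-Glo, with a stated time of 72 h; a lower number here means a stronger inhibitor, a higher number a weaker inhibitor. Compound 1 gives no number, only a limit of the assay: > 60000 nM. Its place on the scale is therefore known only as the limit of > 60000 nM in this assay, at which 1 of the 2 values shown sits. Among the compounds with values here, compound 2 supplies the only true number, 3600 nM.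

The next compound, compound 3 `C/C=C/C(=O)Nc1cccc(Cn2nc(-c3ccc(Oc4ccccc4)cc3)cc2C(=O)OCC)c1`, keeps the core of compound 1 and changes one place: ethyl in place of hydrogen on an oxygen next to a carbonyl group, or carboxy to ethoxycarbonyl (ethyl in place of hydrogen on an oxygen next to a carbonyl group). Within the data shown here, no measured pair shows what this change does, so the expectation rests on little and stays wide. A move towards a lower number in this assay, meaning a stronger inhibitor, is expected, and it is expected to lie beyond the scatter. A second result that is only a limit remains possible. The expected size is an at least 7.5-fold lower number from compound 1 to compound 3 (0.87 log units; beyond the scatter). For compound 3 the estimated value is 8000 nM, with an expected range from 1500 nM to 60000 nM.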

Compound 3, half-maximal inhibitory concentration: 16700 nM
For compound 3 the middle estimate is 2.1-fold (0.32 log units) below the measured one, within the range that was stated.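

Ethyl in place of hydrogen on an oxygen next to a carbonyl group, which turns carboxy into ethoxycarbonyl, is the first change in the series that can be read as a step in this assay: it gives an at least 3.5-fold lower number from compound 1 to compound 3 (0.55 log units; beyond the scatter). The size of this step is only a lower bound because its starting point is a limit and not a number: the limit of > 60000 nM in this assay, at which 1 of the 3 values shown sits. Within the data shown here, the core of compound 1 gets its only true number with compound 3, 16700 nM, so further changes on this core now have a measured reference point.

The compounds shown leave open whether this step belongs to ethyl as such or would also appear with methyl, a longer chain on the same oxygen, or a primary amide in place of the ester. They also leave open whether carboxy to ethoxycarbonyl gives a step of similar size on the core of compound 2, where the carboxylic acid already carries a true number.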